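Triazolyl to piperazinyl side chain: outlook for compound 3

This account rests on a few compounds, and the source may have more. Where it says the series, first, only, none or still open, it means among the compounds named here.

- compound 1 `CCCN1CCN(CCCCn2c3c(c4ccccc42)C(=O)c2c[n+]([O-])c4ccccc4c2C3=O)CC1` gives 6830 nM
- compound 2 `O=C1c2c[n+]([O-])c3ccccc3c2C(=O)c2c1c1ccccc1n2Cc1cn(C[C@@H](O)CO)nn1` gives 490 nM

In a toxicity assay on L02 cells (Homo sapiens) for cytotoxicity, read by MTT assay, with a stated time of 72 h (a lower number here means a stronger inhibitor, a higher number a weaker inhibitor), compound 2 holds the lower of the two numbers, and its gap to compound 1 lies beyond the scatter. The unmeasured compound 3 `CN1CCN(CCCCCn2c3c(c4ccccc42)C(=O)c2c[n+]([O-])c4ccccc4c2C3=O)CC1` departs from compound 2 as follows: 4-(4-methylpiperazin-1-yl)butyl in place of 1-(2,3-dihydroxypropyl)-1H-1,2,3-triazol-4-yl on a saturated chain carbon bound to an aromatic nitrogen and so 4-(4-methylpiperazin-1-yl)butyl replaces the triazolyl group on a saturated chain carbon bound to an aromatic nitrogen.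

Among the measured compounds shown here, only one measured step bears on this change: a 14-fold lower number from compound 1 to compound 2 (1.14 log units; beyond the scatter) and it is large. That step brought in the same triazolyl group in place of 3-(4-propylpiperazin-1-yl)propyl, whereas the new change takes this group out again for another piperazine-ended chain. A large step toward a higher number is therefore expected in this assay though perhaps smaller than the measured one. For the measured compounds named here, the two piperazine-ended groups are not identical, and no measured pair shows what that difference does. The expected move is an estimated 8.2-fold higher number from compound 2 to compound 3 (0.91 log units; beyond the scatter) on this single precedent. Compound 3 is estimated at 4000 nM with 1300 nM to 12000 nM as the expected range.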

Compound 3, half-maximal inhibitory concentration: 1640 nM
Estimate against measurement, compound 3: 2.4-fold (0.39 log units) above; the measured number falls inside the stated range.
By their numbers in this assay, from the lowest: compound 2; then compound 3; then compound 1.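

In this assay, a piperazine-ended chain does not by itself hold the number at the level of compound 1: a 4.2-fold lower number from compound 1 to compound 3 (0.62 log units; beyond the scatter) comes with (4-methylpiperazin-1-yl)methyl in place of 4-propylpiperazin-1-yl on a saturated chain carbon, four bonds along the chain from an aromatic nitrogen, so this position responds to changes within the piperazine-ended chains as well as to the exchange with the triazolyl group. Compound 2 still keeps the lowest number of the three, with a 3.3-fold higher number from compound 2 to compound 3 (0.52 log units; beyond the scatter) on going to 4-(4-methylpiperazin-1-yl)butyl, and this modest step shows that only part of the earlier large gap remains with this other piperazine-ended chain. Nothing available gives a reason for either step.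

The step between the two piperazine-ended compounds alters the chain and the group on the piperazine together, and the compounds shown do not separate the two changes. Also open, as far as these compounds go, is where a morpholine at the chain end, or a piperazine carrying a hydrogen on that nitrogen in place of methyl or propyl, would fall on this scale.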